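This account rests on a few compounds, and the source may have more. Where it says the series, first, only, none or still open, it means among the compounds named here.

Measured in a functional assay on SK-OV-3 cells (Homo sapiens) for cytotoxicity, read by MTT assay, with a stated time of 48 h; a higher number here means a weaker inhibitor, a lower number a stronger inhibitor:
compound 1 `O=C(/C=C/c1ccc2c(c1)B(O)OC2)c1ccc(I)cc1`: 4200 nM
compound 2 `O=C(/C=C/c1ccc2c(c1)B(O)OC2)c1ccccc1F`: 3700 nM
compound 3 `O=C(/C=C/c1ccc2c(c1)B(O)OC2)c1cccc(O)c1`: 3800 nM

Compound 1 has the highest number of the three, yet both a 1.1-fold lower number from compound 1 to compound 2 (0.06 log units; within the scatter) and a 1.1-fold lower number from compound 1 to compound 3 (0.04 log units; within the scatter) fall within the scatter, as does a 1.0-fold higher number from compound 2 to compound 3 (0.01 log units; within the scatter), so the three cannot be told apart in this assay. Compound 4 `O=C(O)c1ccc(C(=O)/C=C/c2ccc3c(c2)B(O)OC3)cc1` differs from compound 1 by carboxy in place of iodo on an aromatic carbon. Every measured step changes the group on the same aromatic ring attached to the carbonyl carbon, and none of them moved the number beyond the scatter. For the measured compounds named here, no measured step brings in a carboxy group, so the evidence for compound 4 is indirect. Given those steps, compound 4 is expected to sit close to compound 1, with a 1.1-fold lower number from compound 1 to compound 4 (0.02 log units; within the scatter) estimated to be within the scatter, at about 4000 nM (range 2000 nM to 8500 nM).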

Compound 4, half-maximal inhibitory concentration: > 100000 nM
Compound 4 gave a limit, no number; the forecaster's own chance of this, stated with the estimate: 5%; middle value at least 25-fold (1.39 log units) away from the limit.
By their numbers in this assay, from the lowest: compounds 2, 3 and 1 (each within the scatter of the next). At a limit, above all of these: compound 4.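

In this assay, the earlier changes on the aromatic ring attached to the carbonyl carbon all stayed within the scatter, whereas carboxy in place of iodo brings an at least 23-fold higher number from compound 1 to compound 4 (1.37 log units; beyond the scatter). This position, para to a large group, is therefore not indifferent to the group it carries, and compound 1 shows that iodo is accepted there while carboxy is not. For compound 4 the value is a limit, not a number: the limit of > 100000 nM in this assay, at which 1 of the 4 values shown sits.

Going by these compounds, whether a methyl ester, a primary amide or an amine on the same carbon would track iodo or carboxy stays open. On these data alone, how far the value of compound 4 lies past its limit also stays open.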